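Chloro in Place of Methyl, Tried on Two Cores

A few compounds are considered here, and "the series" means these few. Any claim that something is new, unique, unknown or untested is made for them only; others in the source may bear on it.

The study compares four compounds that share a propyl chain linking a piperazine bearing a chlorophenyl group to a five-membered ring carrying a para-substituted phenyl group. Compound 1 `Cc1ccc(-c2nnc(SCCCN3CCN(c4cccc(Cl)c4)CC3)[nH]2)cc1` and compound 2 `Clc1ccc(-c2nnc(SCCCN3CCN(c4cccc(Cl)c4)CC3)[nH]2)cc1` are built on one core; compound 3 `Cc1ccc(-c2nn(CCCN3CCN(c4cccc(Cl)c4)CC3)c(=S)[nH]2)cc1` and compound 4 `S=c1[nH]c(-c2ccc(Cl)cc2)nn1CCCN1CCN(c2cccc(Cl)c2)CC1` are built on another, and the difference between the two cores is not broken down here.

In a functional assay on U-937 cells (Homo sapiens) for cytotoxicity, read by MTT assay, with a stated time of 24 h (a higher number here means a weaker inhibitor, a lower number a stronger inhibitor), compound 1 gives 257000 nM. In this assay compound 2 reaches only a limit, > 300000 nM, and not a number. The change between them, (chloro in place of methyl on an aromatic carbon), therefore produced an at least 1.1-fold higher number from compound 1 to compound 2 (0.06 log units; that floor lies within the scatter). Compound 3 likewise reaches only a limit in this assay, > 300000 nM, and not a number. The step from compound 3 to compound 4 is the same change, (chloro in place of methyl on an aromatic carbon), and its place is described in the same words as before. Two of the three values recorded sit at the limit of > 300000 nM in this assay, at which 2 of the 3 values shown sit, so the outcome for compound 4 can hardly be resolved below that point.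

He expects the step that the limit leaves unreadable from compound 3 to compound 4, an expectation that rests on the earlier step because the same change gave an at least 1.1-fold higher number from compound 1 to compound 2 (0.06 log units; that floor lies within the scatter) and because compound 3 already sits at > 300000 nM. For compound 4 in this assay the estimate is 400000 nM, with a likely range from 250000 nM to 900000 nM, and most probably the assay again reports only a limit.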

Compound 4, half-maximal inhibitory concentration: 28200 nM
Estimate against measurement, compound 4: 14-fold (1.15 log units) above; measured number below the stated range.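

In this assay, the change from 4-methylphenyl to 4-chlorophenyl gave an at least 10-fold lower number from compound 3 to compound 4 (1.02 log units; beyond the scatter), so on the core of compound 3 this single replacement of methyl by chloro left a large mark on the read-out. The change therefore did not carry over unaltered from one core to the other in this series, and the two steps can be told apart: the same change on two cores in this assay, an at least 1.1-fold higher number (0.06 log units; that floor lies within the scatter) from compound 1 to compound 2 and an at least 10-fold lower number (1.02 log units; beyond the scatter) from compound 3 to compound 4, at least 12-fold (1.09 log units) apart, beyond the scatter of two such steps. For the compounds shown here, this comparison rests on only two pairs of compounds and shows neither why the cores part nor the true size of either step, since each of the two steps is read against a limit and not against a number: the limit of > 300000 nM in this assay, at which 2 of the 4 values shown sit.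

The compounds shown leave open whether the same divergence would appear with other groups on that aromatic carbon, such as fluoro, methoxy or an amine, or on any core beyond these two. They also leave open whether it would persist with a longer chain in place of the propyl link, and whether the core of compound 1 can give a large step of this kind at all.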